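Phenylsulfamoyl replacement on the aryl of compound 3

This account rests on a few compounds, and the source may have more. Where it says the series, first, only, none or still open, it means among the compounds named here.

Compound 3 `CC#C[C@H]1CN(S(=O)(=O)c2ccc(N)nc2)CCN1c1ccc(S(=O)(=NC)C(F)(F)F)cc1` gives 2060 nM in an assay on cells (Hepatocyte) for inhibition of glucokinase regulatory protein (Mus musculus), with stated times of 20 min and 40 min (on this read-out lower numbers stand for an effect already at smaller amounts and higher numbers for an effect only at larger amounts of compound), the highest number of the three measured. Compound 1 `CC#C[C@H]1CN(S(=O)(=O)c2ccc(N)nc2)CCN1c1ccc([C@@](O)(CO)C(F)(F)F)cc1` gives 89 nM and compound 2 `CC#C[C@H]1CN(S(=O)(=O)c2ccc(N)nc2)CCN1c1ccc(S(=N)(=O)C2CC2)cc1` gives 208 nM; the steps into compound 3 are a 23-fold higher number from compound 1 to compound 3 (1.36 log units; beyond the scatter) and a 9.9-fold higher number from compound 2 to compound 3 (1.00 log units; beyond the scatter), while a 2.3-fold higher number from compound 1 to compound 2 (0.37 log units; beyond the scatter) is smaller. Compound 4 `CC#C[C@H]1CN(S(=O)(=O)c2ccc(N)nc2)CCN1c1ccc(S(=O)(=O)Nc2ccccc2)cc1` differs from compound 3 by a group of 10 heavy atoms (6 carbon, 1 nitrogen, 2 oxygen, 1 sulfur; one six-membered aromatic ring of carbon only) in place of a group of 8 heavy atoms (2 carbon, 1 nitrogen, 1 oxygen, 3 fluorine, 1 sulfur; no ring), on an aromatic carbon. Both measured steps into compound 3 show that the group on this aromatic carbon moves the read-out strongly, and that the trifluoromethyl-bearing sulfur group of compound 3 is the weakest of the three. Among the measured compounds shown here, no measured step covers the phenylsulfamoyl group itself, so the expected direction rests only on compound 3 being the weakest: a lower number is expected, a 2.9-fold lower number from compound 3 to compound 4 (0.47 log units; beyond the scatter), with wide uncertainty. Compound 4 is estimated at 700 nM, range 150 nM to 3000 nM.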

Compound 4, half-maximal effective concentration: > 12500 nM
Compound 4: a limit, no number; the forecaster's own chance of this, stated with the estimate: 5%; middle value at least 17-fold (1.25 log units) from the limit.
By their numbers in this assay, from the lowest: compound 1; then compound 2; then compound 3. At a limit, above all of these: compound 4.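

In this assay compound 4 stands at a limit, not a number: the limit of > 12500 nM in this assay, at which 1 of the 4 values shown sits. Phenylsulfamoyl on this aromatic carbon gives an at least 6.0-fold higher number from compound 3 to compound 4 (0.78 log units; beyond the scatter), an at least 60-fold higher number from compound 2 to compound 4 (1.77 log units; beyond the scatter) and an at least 140-fold higher number from compound 1 to compound 4 (2.14 log units; beyond the scatter), and the true size of each step stays unknown. The earlier changes at this place all stayed within the measurable range, whereas this one takes the read-out to the assay limit.

On these data alone, it remains open whether the step goes with the phenyl ring or with the sulfamoyl link. An unsubstituted sulfamoyl group or a methylsulfonyl group on this carbon would separate the two.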